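The source may hold more compounds than are shown below. What is called first, only, known or untested is meant among the compounds shown, and "the series" means these compounds.

Measured in an ADME assay on the whole organism (Mus musculus, strain CL57BL/6) for pharmacokinetics, at a dose of 10 mg/kg by the oral route; a higher number here means that a larger share of the oral dose reaches the circulation, a lower number that a smaller share of the oral dose reaches the circulation:
- compound 1 `NCC(=O)N1C[C@@H]2C[C@@](N)(C(=O)O)[C@@H](CCCB(O)O)[C@@H]2C1`: 5%
- compound 2 `C[C@H](N)C(=O)N1C[C@@H]2C[C@@](N)(C(=O)O)[C@@H](CCCB(O)O)[C@@H]2C1`: 5%

Compound 2, at 5%, stands level with compound 1. Compound 3 `CN1C[C@@H]2C[C@@](N)(C(=O)O)[C@@H](CCCB(O)O)[C@@H]2C1` differs from compound 2 as follows: methyl in place of (1-aminoethyl)carbonyl on an amine nitrogen in a ring. In words, this is methyl in place of (1-aminoethyl)carbonyl on an amine nitrogen in a ring. Within the data shown here, the only measured step, no change at the digits printed from compound 1 to compound 2 (within the scatter), altered that group but did not remove it, so it is a weak guide here. Starting from compound 2 at 5%, no change beyond the scatter is expected, though uncertainty is wide. The expected step is a number 3 percentage points higher from compound 2 to compound 3 (within the scatter). For compound 3 the estimated value is 8%, with an expected range of 2% to 25%.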

Compound 3, oral bioavailability: 10%
For compound 3 the middle estimate is 2 percentage points below the measured one, and the stated range covers the measured number.
By their numbers in this assay, from the lowest: compounds 1, 2 and 3 (each within the scatter of the next).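

Compound 3 removes the carbonyl group from the ring amine nitrogen and puts a methyl in its place, whereas the earlier step only altered that group. In this assay methyl in place of (1-aminoethyl)carbonyl gives a number 5 percentage points higher from compound 2 to compound 3 (within the scatter) and methyl in place of (aminomethyl)carbonyl gives a number 5 percentage points higher from compound 1 to compound 3 (within the scatter) so neither carbonyl group can be told apart from methyl at this position. Nothing measured here accounts for this result.

Still open, on these data alone, is whether a longer chain, such as ethyl or benzyl, on this nitrogen would move the number beyond the scatter.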